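Cytotoxicity on macrophages along a benzyl substitution series

This account rests on a few compounds, and the source may have more. Where it says the series, first, only, none or still open, it means among the compounds named here.

Measured compounds:
compound 1 `CCn1cc2ccc(N/C(C)=C3\C(=O)C=C(C)OC3=O)cc2n1` — > 100000 nM
compound 2 `C=CCn1cc2ccc(N/C(C)=C3\C(=O)C=C(C)OC3=O)cc2n1` — > 100000 nM

In an ADME assay on RAW264.7 cells (Mus musculus) for cytotoxicity, read by resazurin assay, with a stated time of 48 h (on this read-out higher numbers stand for lower toxicity in this test and lower numbers for higher toxicity in this test), compound 1 reaches only a limit, > 100000 nM, not a number. In this assay compound 2 likewise gives a limit, > 100000 nM. The change between them, a step that the two limits leave unreadable from compound 1 to compound 2, therefore cannot be sized; what is known is summed up by the limit of > 100000 nM in this assay, at which 2 of the 2 values shown sit. Compound 2 thus stands at the ceiling of what this assay reports, alongside compound 1.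

Compound 3 `CC1=CC(=O)/C(=C(/C)Nc2ccc3cn(Cc4ccc(C)cc4)nc3c2)C(=O)O1` is not yet measured. It differs from compound 2 by 4-methylphenyl in place of vinyl on a saturated chain carbon bound to an aromatic nitrogen. Within the data shown here, the only measured step on this shared core, a step that the two limits leave unreadable from compound 1 to compound 2, is unreadable, so no direction can be drawn from it; the pair shows only that both limits sit at the same value. For compound 3 the step that the limit leaves unreadable from compound 2 to compound 3 is estimated to be small or none beyond the scatter, most likely ending again at a limit. Compound 3 is expected to give about 120000 nM, within a range from 40000 nM to 400000 nM, in this assay.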

Compound 3, half-maximal cytotoxic concentration: > 100000 nM
Compound 3: a limit, no number; the forecaster's own chance of this, stated with the estimate: 75%; the middle value lies beyond the limit too.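

In this assay compound 3 gives > 100000 nM, which is a limit and not a number. The steps from compound 1 and compound 2 to compound 3 therefore cannot be read. The compounds shown leave open at what concentration any of the three would become toxic to these cells, and whether the group on the shared core alters that.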